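The compounds below may be only part of what the source reports. "The series", "measured", "known", "first", "only" and "open" are said of these compounds alone.

Working notes on the shared core of compound 1 `Oc1cccc(NC(=S)Nc2ccc3[nH]ccc3c2)c1` and compound 2 `OCc1ccc(NC(=S)Nc2ccc3[nH]ccc3c2)cc1`, both carried through an ADME assay on isolated protein for inhibition of peroxidase (Raphanus sativus), read by fluorescence and Amplex Red, tested at 5 uM; a higher number here means a weaker effect of the compound at the concentration tested, a lower number a stronger effect. In this assay compound 1 gives 81.4% and compound 2 gives 88.3%. The two numbers sit within the scatter of each other, so neither compound can be set apart from the other; both leave most of the enzyme activity intact at the concentration tested, and compound 2 therefore stands at the weak end of what is seen so far, with compound 1 at its side.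

Compound 3 `CC(=O)c1ccc(NC(=S)Nc2ccc3[nH]ccc3c2)cc1` is the next member to be measured in this assay. Against compound 2 the change is acetyl in place of hydroxymethyl on an aromatic carbon. Within the data shown here, no step between two measured compounds describes a change of this kind, so the only guide is that the two substituents seen so far give the same weak read-out. On that basis no step beyond the scatter is expected, in either direction, and the expected step is a number 3.3 percentage points lower from compound 2 to compound 3 (within the scatter). For compound 3 in this assay the expectation is 85%, with a range from 70% to 97%.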

Compound 3, a percentage reported as activity, at one concentration (the size of the read-out at that concentration, not a potency): 66.3%
Beside the measured number, compound 3's estimate is 18.7 percentage points above it; measured number outside the range, below it.
By their numbers in this assay, from the lowest: compound 3; then compounds 1 and 2 (each within the scatter of the next).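

In this assay, among these compounds, the position para to a large group does not tolerate every substituent equally: acetyl in place of hydroxymethyl gives a number 22 percentage points lower from compound 2 to compound 3 (beyond the scatter) and so brings a step beyond the scatter, which the earlier compounds could not show, as they offered no pair differing in one place. The change enters one more heavy atom and a double bond outside aromatic rings and leaves 0 hydrogen-bond donors where hydroxymethyl had 1, but a single step cannot tell which of these differences, if any, goes with the lower number. Nothing measured on these compounds bears on why the number moves, so the step stands as an observation only.

Open, as far as these compounds go, is whether the step follows the carbonyl of acetyl itself, which a longer chain ending in a carbonyl, a carboxylic acid or a methyl ester at the same position would test, along with an amine or a methoxy group as non-carbonyl substituents. Also open, from the compounds shown here alone, is whether the same exchange of hydroxymethyl for acetyl gives a step of similar size on other members.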